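Swapping bromo for methyl on a cytotoxicity-tested oxadiazole

A few compounds are considered here, and "the series" means these few. Any claim that something is new, unique, unknown or untested is made for them only; others in the source may bear on it.

The measured compounds and their readings:
- compound 1, `CC(=O)OC[C@H]1O[C@H](OC[C@H](Cn2cc(COc3ccc(-c4noc(NC5CCCCC5)n4)cc3)nn2)OC(C)=O)C=C[C@@H]1OC(C)=O`, 99.5 ug/mL
- compound 2, `C#CCN(c1nc(-c2cccc(Br)c2)no1)C1CCCCC1`, 53.5 ug/mL
- compound 3, `CC(=O)OC[C@H]1O[C@H](OC[C@H](Cn2cc(-c3ccc(-c4noc(NC5CCCCC5)n4)cc3)nn2)OC(C)=O)C=C[C@@H]1OC(C)=O`, 79.8 ug/mL

All three were tested in an ADME assay on HepG2 cells (Homo sapiens) for cytotoxicity, read by MTT assay, with a stated time of 48 h; a higher number here means that more compound is tolerated, a lower number that less compound is tolerated. Compound 2 gives the lowest of the three numbers, but the gap to its neighbours is small: compound 3 sits closest, and even the furthest, compound 1, lies within the usual scatter of this assay. So on the present evidence the three compounds tolerate a broadly similar amount, and no ranking among them can be claimed.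

The unmeasured compound 4, `C#CCN(c1nc(-c2cccc(C)c2)no1)C1CCCCC1`, differs from compound 2 in one place: methyl in place of bromo on an aromatic carbon. The group leaves and the group that enters are each a single heavy atom, neither carries a donor or acceptor, and the change sits on an aromatic carbon of a six-membered aromatic ring of carbon only, meta to a large group.

Among the measured compounds shown here, no pair of measured compounds shows such a swap, so the data give no direct step to lean on. A change this small is not expected to move the reading beyond the scatter in this assay, in either direction. Compound 4 is therefore expected to give about 55 ug/mL, with a plausible range from 27 ug/mL to 110 ug/mL, meaning an expected step of a 1.0-fold higher number from compound 2 to compound 4 (0.01 log units; within the scatter).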

Compound 4, half-maximal cytotoxic concentration: 44.4 ug/mL
Compound 4: the middle estimate sits 1.2-fold (0.09 log units) above what was measured, within the range that was stated.
By their numbers in this assay, from the lowest: compounds 4, 2, 3 and 1 (each within the scatter of the next, the first and the last beyond it).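

Among the compounds shown here, the earlier compounds offered no pair differing in one place, so this is the first direct look at the aromatic carbon that carries the bromo group. In this assay the change from 3-bromophenyl to 3-methylphenyl gives a 1.2-fold lower number from compound 2 to compound 4 (0.08 log units; within the scatter) and so shows that, for this one pair, methyl can stand in place of bromo without a shift that can be told apart from ordinary repeat variation. Nothing in the available evidence accounts for this result or links it to any property of either group.

Bromo and methyl are the only groups shown at this place, and both are small groups of a single heavy atom with no hydrogen-bond donors or acceptors, so they probe only a narrow part of what could sit there. Whether a larger or more strongly interacting group, such as a methoxy group, an amine or a carboxylic acid, would also stay within the scatter on this same aromatic carbon remains an open question.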